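This account rests on a few compounds, and the source may have more. Where it says the series, first, only, none or still open, it means among the compounds named here.

In a functional assay on HeLa cells (Homo sapiens) for antiproliferative activity, read by MTT assay, with a stated time of 72 h; on this read-out higher numbers stand for weaker inhibition and lower numbers for stronger inhibition:
Compound 1 `COc1cccc(N2C(=O)COc3ccc(-c4cnc5ccccc5c4)cc32)c1`: 11400 nM
Compound 2 `COc1cccc(N2C(=O)COc3ccc(-c4ccc(O)cc4)cc32)c1`: > 40000 nM (a limit of the assay)
Compound 3 `COc1ncc(-c2ccc3c(c2)N(C2CC2)C(=O)CO3)cc1NS(=O)(=O)c1ccc(F)cc1`: 6030 nM

Compound 1, with 11400 nM, lies within the usual scatter of compound 3. Compound 2 is recorded only as a limit of the assay.

The account now turns to compound 4 `O=C1COc2ccc(-c3cnc4ccccc4c3)cc2N1`, which keeps the core of compound 1. The change (hydrogen in place of 3-methoxyphenyl on an amide-type nitrogen in a ring) is hydrogen in place of 3-methoxyphenyl on an amide-type nitrogen in a ring. Among the measured compounds shown here, no measured pair shows this change alone, so any forecast in this assay remains loose. Compound 3 lacks the 3-methoxyphenyl and still gives 6030 nM, although it also differs from compound 1 elsewhere. A complete loss of the read-out is therefore not assumed, but a moderate move towards weaker inhibition is expected, and the result may reach the assay limit. The expected change is a 1.9-fold higher number from compound 1 to compound 4 (0.29 log units; within the scatter). For compound 4 the estimated value is 22000 nM, with an expected range from 8000 nM to 50000 nM.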

Compound 4, half-maximal inhibitory concentration: > 40000 nM
Compound 4 ended at the assay's limit; the forecaster's own chance of this, stated with the estimate: 40%; middle value at least 1.8-fold (0.25 log units) from the limit.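

In this assay, hydrogen in place of 3-methoxyphenyl on the amide-type nitrogen gives an at least 3.5-fold higher number from compound 1 to compound 4 (0.54 log units; beyond the scatter), the only comparison shown that changes this position alone. With the rest of the structure unchanged, this pair shows that the bare nitrogen does not keep the inhibition seen with the 3-methoxyphenyl group. Compound 4 is recorded only as a limit of the assay, so the step sets a lower bound and its full size remains unknown: the limit of > 40000 nM in this assay, at which 2 of the 4 values shown sit.

On these data alone, it remains open whether a methyl or a benzyl group on this nitrogen would keep the read-out of compound 1. The compounds shown also do not tell whether the methoxy group matters on its own, which an unsubstituted phenyl group at this position could test.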